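A few compounds are considered here, and "the series" means these few. Any claim that something is new, unique, unknown or untested is made for them only; others in the source may bear on it.

Of the two compounds with a number in an assay on Sf9 cells for inhibition of mitogen-activated protein kinase kinase kinase 14 variant S549D (Homo sapiens), with a stated time of 30 min, in the presence of a further agent that is not named here (a lower number here means a stronger inhibitor, a higher number a weaker inhibitor), compound 1 `C#Cc1ccc2ncn(-c3ccnc(N)n3)c2c1` stands lowest. In this assay compound 1 gives 251 nM, whereas compound 2 `C=CC(=O)NCCCCc1ccc2ncn(-c3ccnc(N)n3)c2c1` gives 501000 nM, a gap far beyond the scatter. Compound 3 `C#Cc1ccnc(C#Cc2ccc3ncn(-c4ccnc(N)n4)c3c2)c1` has not yet been measured. It differs from compound 1 by 4-ethynylpyridin-2-yl in place of hydrogen on a triple-bonded carbon, on a triple-bonded carbon whose other neighbour is a triple-bonded carbon. Going by the values given here, no measured pair shows a change of this kind, so its size is uncertain. The expected step is a 1.8-fold higher number from compound 1 to compound 3 (0.25 log units; within the scatter), a small weakening in this assay within or just beyond the scatter. Compound 3 is estimated at 450 nM, between 80 nM and 3000 nM.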

Compound 3, half-maximal inhibitory concentration: 316 nM
Compound 3: middle estimate off by 1.4-fold (0.15 log units), on the high side; the range from low to high includes it.
By their numbers in this assay, from the lowest: compounds 1 and 3 (each within the scatter of the next); then compound 2.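

In this assay, 4-ethynylpyridin-2-yl in place of hydrogen on a triple-bonded carbon gives a 1.3-fold higher number from compound 1 to compound 3 (0.10 log units; within the scatter), so compound 3 cannot be told apart from compound 1. Going by these compounds alone, this is the first step at this position, and it shows that the position accepts a six-membered aromatic ring carrying a further triple bond without a change beyond the scatter. No measurement offered here gives a reason for this result. Open, on these data alone, is whether a plain phenyl, or an aminomethyl group on the same triple-bonded carbon, would read the same. Also open, as far as these compounds go, is what the ring nitrogen and the ethynyl of the entering group each contribute.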